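Fluoro for (methylsulfonyl)oxy at the saturated ring carbon

The source may report more compounds than this note shows. Statements on the series, on what has been measured and on what is new or still open speak of the compounds shown alone.

Compound 2 `CS(=O)(=O)O[C@@H]1[C@@H](O)[C@H](n2ccc(N)nc2=O)O[C@@H]1CO` holds the highest of the two numbers in a functional assay on P815 cells (Mus musculus) for antiproliferative activity (on this read-out lower numbers stand for stronger inhibition and higher numbers for weaker inhibition), giving 22 ug/mL; its nearest neighbour, compound 1 `CS(=O)(=O)O[C@@H]1[C@@H](O)[C@H](n2cc(F)c(N)nc2=O)O[C@@H]1CO`, gives 6 ug/mL. Among the compounds with values here, the only measured step, a 3.7-fold higher number from compound 1 to compound 2 (0.56 log units; beyond the scatter), concerns hydrogen in place of fluoro on an aromatic carbon and does not touch the present change. Compound 3 `Nc1ccn([C@@H]2O[C@H](CO)[C@H](F)[C@H]2O)c(=O)n1` differs from compound 2 by fluoro in place of (methylsulfonyl)oxy on a saturated ring carbon, with the (methylsulfonyl)oxy leaving and fluoro entering. Within the data shown here, no measured step bears on this exchange, so no direction can be read from the data. Compound 3 is therefore expected near 20 ug/mL, within 5 ug/mL to 80 ug/mL. The expected step of a 1.1-fold lower number from compound 2 to compound 3 (0.04 log units; within the scatter) would stay within the scatter.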

Compound 3, concentration for 50% inhibition: > 100 ug/mL
Compound 3: no number, only a limit; the forecaster's own chance of this, stated with the estimate: 10%; middle value at least 5.0-fold (0.69 log units) from the limit.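

Fluoro in place of (methylsulfonyl)oxy on the saturated ring carbon gives an at least 4.5-fold higher number from compound 2 to compound 3 (0.65 log units; beyond the scatter) in this assay. Within the data shown here, this is the first sign that the saturated ring carbon, and not only the aromatic carbon, matters for the read-out, and within this pair the (methylsulfonyl)oxy is the better of the two groups. The result for compound 3 is a limit, not a number: the limit of > 100 ug/mL in this assay, at which 1 of the 3 values shown sits.

Going by these compounds, whether the sulfur-bearing group itself is needed stays open, since an amine or a methoxy on this carbon could separate it from other groups. Also open, on these data alone, is how fluoro on the aromatic carbon, as in compound 1, would combine with fluoro on the saturated carbon.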